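Fluoro on the fused core: notes toward compound 4

The compounds below may be only part of what the source reports. "The series", "measured", "known", "first", "only" and "open" are said of these compounds alone.

Measured so far, in a functional assay on HT-29 cells (Homo sapiens) for cytotoxicity, read by MTT assay, with a stated time of 72 h; a higher number here means a weaker inhibitor, a lower number a stronger inhibitor:
- compound 1, `O=C(Nc1nc2ccc(Cl)cc2s1)c1cn(-c2ccccc2)nc1-c1ccccc1`, gives 7810 nM
- compound 2, `O=C(Nc1nc2ccc(Cl)cc2s1)c1cn(-c2ccccc2)nc1-c1ccc(F)cc1`, gives 3320 nM
- compound 3, `O=C(Nc1nc2ccccc2s1)c1cn(-c2ccccc2)nc1-c1ccc(Cl)cc1`, gives 13700 nM

Compounds 1 and 2 differ by fluoro in place of hydrogen on an aromatic carbon, and that change brings a 2.4-fold lower number from compound 1 to compound 2 (0.37 log units; beyond the scatter). Compound 3 stands with the highest number of the three; against compound 1 the gap is within the scatter, against compound 2 it is beyond it. The difference between the core of compound 3 and the core of compound 1 is not broken down here.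

Compound 4, `O=C(Nc1nc2ccc(F)cc2s1)c1cn(-c2ccccc2)nc1-c1ccc(Cl)cc1`, is not yet measured. It differs from compound 3 by fluoro in place of hydrogen on an aromatic carbon. Among the compounds with values here, this is the same kind of change as the one from compound 1 to compound 2, but not the same: there the place was "para to a large group" on a six-membered ring of carbon only; here the place is on a six-membered aromatic ring of carbon only that is part of a fused or bridged system of two rings, "meta to a fused ring; para to a fused ring".

Within the data shown here, for compound 4 in this assay a step of about a 1.7-fold lower number from compound 3 to compound 4 (0.23 log units; within the scatter) is expected, somewhat smaller than the one seen from compound 1 to compound 2 because that step, a 2.4-fold lower number from compound 1 to compound 2 (0.37 log units; beyond the scatter), was made at a different place and its size need not carry over. The estimate for compound 4 is 8000 nM, between 3000 nM and 20000 nM.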

Compound 4, half-maximal inhibitory concentration: 4970 nM
For compound 4 the middle estimate is 1.6-fold (0.21 log units) above the measured one, within the range that was stated.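

In this assay, the change from 1,3-benzothiazol-2-yl to 6-fluoro-1,3-benzothiazol-2-yl brings a 2.8-fold lower number from compound 3 to compound 4 (0.44 log units; beyond the scatter), and this step can be set directly against the earlier fluoro step: the same change on two cores in this assay, a 2.4-fold lower number (0.37 log units; beyond the scatter) from compound 1 to compound 2 and a 2.8-fold lower number (0.44 log units; beyond the scatter) from compound 3 to compound 4, 1.2-fold (0.07 log units) apart, within the scatter of two such steps

In these two pairs, then, fluoro in place of hydrogen on an aromatic carbon lowers the number by a like amount on two cores, even though the place differs: on a ring that is part of a fused system of two rings in one pair, and para to a large group on a six-membered ring of carbon only in the other. This does not show that the step will carry over to further cores or places, since two pairs are a thin base, and because core and place change together between them, the share of each cannot be separated.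

The compounds shown leave open whether the same place on the fused system would respond in a similar way to a methoxy group, an amine or a carboxylic acid. They also leave open whether fluoro at one and the same place gives a step of this size on both cores, and whether two fluoro groups on one compound would add up.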